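Pyrrolidine for piperidine on the benzimidazole amide series

The source may report more compounds than this note shows. Statements on the series, on what has been measured and on what is new or still open speak of the compounds shown alone.

Compound 1 `O=C(CN1CCCCC1)Nc1ccc(-c2nc3cc(C(F)(F)F)ccc3[nH]2)cc1` gives 31000 nM in an ADME assay on Vero cells (Chlorocebus sabaeus) for cytotoxicity; a higher number here means that more compound is tolerated, a lower number that less compound is tolerated.
Compound 2 `CC(=O)Nc1ccc(-c2nc3ccccc3[nH]2)cc1` gives > 100000 nM in this assay, a limit of the assay rather than a number.
Compound 3 `O=C(CN1CCCCC1)Nc1ccc(-c2nc3ccccc3[nH]2)cc1` gives > 100000 nM in this assay, again a limit.

For compound 3, then, only a limit is known; its reading sits at the limit of > 100000 nM in this assay, at which 2 of the 3 values shown sit. The two measured steps leading to compound 3 are of different kinds: an at least 3.2-fold higher number from compound 1 to compound 3 (0.50 log units; beyond the scatter), whereas a step that the two limits leave unreadable from compound 2 to compound 3. Neither step touches the ring that is altered next, and the one that involves the amine side chain is unreadable because of the limit of > 100000 nM in this assay, at which 2 of the 3 values shown sit.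

Compound 4 `O=C(CN1CCCC1)Nc1ccc(-c2nc3ccccc3[nH]2)cc1` is the next member; the change is pyrrolidin-1-yl in place of piperidin-1-yl on a saturated chain carbon bound to a carbonyl carbon. For the measured compounds named here, no measured step bears on this change. The expectation is therefore a step that the limit leaves unreadable from compound 3 to compound 4, with compound 4 most likely again returned as a limit. Compound 4 is estimated at 120000 nM in this assay, with a range of 45000 nM to 320000 nM.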

Compound 4, half-maximal cytotoxic concentration: > 100000 nM
Compound 4: a limit, no number; the forecaster's own chance of this, stated with the estimate: 70%; the middle value is on the limit's open side.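

For the compounds shown here, neither the step from compound 3 to compound 4 nor the one from compound 2 to compound 4 can be read, because all three values are limits: the limit of > 100000 nM in this assay, at which 3 of the 4 values shown sit.
The compounds shown leave open whether pyrrolidin-1-yl in place of piperidin-1-yl shifts the reading in this assay at all.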